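This account rests on a few compounds, and the source may have more. Where it says the series, first, only, none or still open, it means among the compounds named here.

Compound 1 `CC1(C)[C@H]2CC[C@]1(C)N(Cc1cn(-c3ccccc3Br)nn1)C(=O)C2`: 60 nM
Compound 2 `CC1(C)[C@H]2CC[C@]1(C)N(Cc1cn(-c3ccc(F)cc3)nn1)C(=O)C2`: 40 nM

Both compounds were tested in a functional assay on LoVo cells (Homo sapiens) for inhibition, read by MTT assay, with a stated time of 24 h; on this read-out higher numbers stand for weaker inhibition and lower numbers for stronger inhibition. There, compound 1 gives 60 nM and compound 2 gives 40 nM. The two stand level, with a measured gap of a 1.5-fold lower number from compound 1 to compound 2 (0.18 log units; within the scatter). Compound 3 `CC1(C)[C@H]2CC[C@]1(C)N(Cc1cn(-c3ccc(O)cc3)nn1)C(=O)C2` keeps the shared core and differs from compound 2 at a single place: hydroxy in place of fluoro on an aromatic carbon. In words, this is hydroxy in place of fluoro on an aromatic carbon, para to a large group. Within the data shown here, no measured step covers this exchange. The nearest evidence is a 1.5-fold lower number from compound 1 to compound 2 (0.18 log units; within the scatter), which involves different groups on the same aromatic ring and stays within the scatter. In this assay, no change beyond the scatter is therefore expected, though with wide uncertainty. The estimated change is a 1.3-fold higher number from compound 2 to compound 3 (0.10 log units; within the scatter). For compound 3 the expected value is 50 nM, with an estimated range of 15 nM to 170 nM.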

Compound 3, half-maximal inhibitory concentration: 410 nM
For compound 3 the middle estimate is 8.2-fold (0.91 log units) below the measured one; the whole stated range lies below it.
By their numbers in this assay, from the lowest: compounds 2 and 1 (each within the scatter of the next); then compound 3.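

Swapping fluoro for hydroxy, para to a large group, is not a neutral exchange in this assay, where it gives a 10-fold higher number from compound 2 to compound 3 (1.01 log units; beyond the scatter) and so moves the number well beyond the scatter that held compound 1 and compound 2 level. The change from 2-bromophenyl to 4-hydroxyphenyl on the aromatic nitrogen gives a 6.8-fold higher number from compound 1 to compound 3 (0.83 log units; beyond the scatter) in the same direction, so compound 3 stands apart from both earlier compounds, and the two different halogen-bearing rings give no hint of this separation. Nothing shown here accounts for the size of this step.

The compounds shown leave open whether a methoxy, an amine or a carboxylic acid at this place would behave like hydroxy or like fluoro. They also leave open whether chloro or a methyl group there would stay level with compound 2.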